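From Formyl to Dihydroxymethyl on a Shared Core

The source may report more compounds than this note shows. Statements on the series, on what has been measured and on what is new or still open speak of the compounds shown alone.

Three compounds share one core and differ only in the group on an aromatic carbon. Compound 1 `CCOC(=O)CCCCCOc1ccc(CNC(C)C)cc1` carries an (isopropylamino)methyl group there, compound 2 `CCOC(=O)CCCCCOc1ccc(C=O)cc1` a formyl group, and compound 3 `CCOC(=O)CCCCCOc1ccc(C(O)O)cc1` a dihydroxymethyl group. In an ADME assay on Raji cells (Homo sapiens) for cytotoxicity, read by CellTiter-Glo and resazurin assay, with a stated time of 72 h (on this read-out higher numbers stand for an effect only at larger amounts of compound and lower numbers for an effect already at smaller amounts), compound 1 gives > 26000 nM, which is a limit of the assay rather than a number. In this assay compound 2 likewise gives > 26000 nM, also a limit of the assay. The step that the two limits leave unreadable from compound 1 to compound 2 cannot be read, since the limit of > 26000 nM in this assay, at which 2 of the 2 values shown sit, leaves both ends open. Compound 2 thus stands at the limit, with no number to place it more exactly. The change to compound 3 is dihydroxymethyl in place of formyl on an aromatic carbon. No measured step bears on this change, so no direction can be drawn from the shown numbers. Compound 3 is therefore expected to give 30000 nM (range 10000 nM to 100000 nM) in this assay, an estimated step that the limit leaves unreadable from compound 2 to compound 3 that stays within the scatter.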

Compound 3, half-maximal effective concentration: > 27100 nM
Compound 3 gave a limit, no number (the forecaster's own chance of this, stated with the estimate: 85%); the middle value does not contradict the limit.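

In this assay compound 3 gives > 27100 nM, which is a limit of the assay and not a number. Within the data shown here, no step among compound 1, compound 2 and compound 3 can be read. From the compounds shown here alone, whether their three groups on the aromatic carbon differ at all in this assay stays open.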